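The compounds below may be only part of what the source reports. "The series", "measured", "known", "first", "only" and "open" are said of these compounds alone.

Compound 3, `Cc1cc(NC(=O)[C@H]2CN(C)C[C@@H]2c2ccc(/C=C/C(=O)Nc3ccccc3N)cc2)ccc1F`, is measured in an in vitro ADME assay on microsomes from liver (Homo sapiens) for pharmacokinetics, read by LC-MS, with a stated time of 10 min, tested at 1 uM (on this read-out higher numbers stand for fast clearance and lower numbers for slow clearance), where compound 3 gives 15 mL/min/kg. Among the three compounds with numbers, compound 3 sits together with compound 2, `COc1cccc(NC(=O)[C@H]2CN(C)C[C@@H]2c2ccc(/C=C/C(=O)Nc3ccccc3N)cc2)c1`, which in this assay gives 14 mL/min/kg, the pair separated only by a 1.1-fold higher number from compound 2 to compound 3 (0.03 log units; within the scatter). Compound 1, `CN1C[C@H](C(=O)Nc2ccc(Br)cc2)[C@@H](c2ccc(/C=C/C(=O)Nc3ccccc3N)cc2)C1`, stands apart from both: in this assay compound 1 gives 3 mL/min/kg, with a 5.0-fold higher number from compound 1 to compound 3 (0.70 log units; beyond the scatter) and a 4.7-fold higher number from compound 1 to compound 2 (0.67 log units; beyond the scatter) marking the distance.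

Compound 4, `CN1C[C@H](C(=O)Nc2ccc(Cl)cn2)[C@@H](c2ccc(/C=C/C(=O)Nc3ccccc3N)cc2)C1`, is not yet measured. Its change from compound 3 is 5-chloropyridin-2-yl in place of 4-fluoro-3-methylphenyl on an amide-type nitrogen. For the measured compounds named here, none of the measured steps exchanges the aromatic ring on that amide-type nitrogen for one bearing a hetero atom; the two steps starting from compound 1 are modest, and the step between compound 2 and compound 3 is within the scatter. A step no larger than the scatter is therefore expected, and compound 4 is estimated at 11 mL/min/kg, between 4 mL/min/kg and 28 mL/min/kg, the expected step being a 1.4-fold lower number from compound 3 to compound 4 (0.13 log units; within the scatter).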

Compound 4, clearance: 13 mL/min/kg
Estimate against measurement, compound 4: 1.2-fold (0.07 log units) below; the measured number falls inside the stated range.
By their numbers in this assay, from the lowest: compound 1; then compounds 4, 2 and 3 (each within the scatter of the next).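

Compound 4 is the only one of the four with a hetero atom in the aromatic ring on the amide-type nitrogen, and in this assay this exchange stays within the scatter, with a 1.2-fold lower number from compound 3 to compound 4 (0.06 log units; within the scatter) and a 1.1-fold lower number from compound 2 to compound 4 (0.03 log units; within the scatter). Compound 1 remains apart, with a 4.3-fold higher number from compound 1 to compound 4 (0.64 log units; beyond the scatter), so among the four groups at this place only 4-bromophenyl stands off from the rest. Nothing measured here explains that separation or the absence of a larger step with the pyridine ring.

The compounds shown leave open whether the separation of compound 1 follows the bromine or the ring that carries it, which a phenyl ring bearing chlorine or a pyridine ring bearing bromine would help to separate. Also open, on these data alone, is how a ring carrying an amine or a carboxylic acid would read at this place.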